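Adding a Methoxy Group to Compound 1

The source may report more compounds than this note shows. Statements on the series, on what has been measured and on what is new or still open speak of the compounds shown alone.

Measured in a functional assay on PC-3 cells (Homo sapiens) for cytotoxicity; on this read-out lower numbers stand for stronger inhibition and higher numbers for weaker inhibition:
compound 1, `O=C(CCCCCCC(=O)Nc1nc2ccccc2s1)NO`: 5.44 ug/mL
compound 2, `CCOc1ccc2nc(NC(=O)CCCCC(=O)NO)sc2c1`: 6.69 ug/mL

Of the compounds shown here, two have numbers so far. Compound 1 gives the lowest of the two, and the nearest neighbour, compound 2, sits within the usual scatter of it, so the two cannot be told apart by this read-out alone. Going by the values given here, compound 2 also differs from compound 1 in more than one place, so no single step can be drawn between them.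

Compound 3, `COc1ccc2nc(NC(=O)CCCCCCC(=O)NO)sc2c1`, has not yet been measured in this assay. The change from compound 1 to compound 3 is methoxy in place of hydrogen on an aromatic carbon. Among the compounds with values here, no measured pair shows the effect of this change by itself, so there is nothing to lean on except the closeness of compound 1 and compound 2, which share a related core with different substituents and chain lengths yet land within the scatter of each other. The step of a 1.0-fold higher number from compound 1 to compound 3 (0.00 log units; within the scatter) is therefore expected to be none beyond the scatter, in no set direction. Compound 3 is estimated at 5.5 ug/mL, with a range from 2.5 ug/mL to 12 ug/mL.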

Compound 3, half-maximal inhibitory concentration: 1.56 ug/mL
Compound 3: middle estimate off by 3.5-fold (0.55 log units), on the high side, and the stated range ends above it.
By their numbers in this assay, from the lowest: compound 3; then compounds 1 and 2 (each within the scatter of the next).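

In this assay, methoxy in place of hydrogen on this aromatic carbon gives a 3.5-fold lower number from compound 1 to compound 3 (0.54 log units; beyond the scatter) and so brings stronger inhibition of the cells, a modest step but one that lies beyond the usual scatter. Going by these compounds alone, this is the first direct sign that the position is not indifferent: a small addition of two heavy atoms, with no ring and no net charge, is enough to shift the read-out, something that compound 1 and compound 2 could not show, as they differ in more than one place. No measurement here accounts for why this change has this effect, so the step stands as an observation and not as an explanation.

A single substitution at a single carbon leaves open whether the gain belongs to methoxy in particular or would also appear with another group there, such as a hydroxyl, a chlorine atom or an amine. From the compounds shown here alone, compound 2 carries ethoxy but also differs from compound 3 in its chain, so it cannot show how a larger alkoxy group would behave on its own, and whether the same gain would hold at other carbons of the ring also remains unknown.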